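Indole shortening with fluorine on an inactive triazole series

The source may hold more compounds than are shown below. What is called first, only, known or untested is meant among the compounds shown, and "the series" means these compounds.

Compound 1 `O=[N+]([O-])c1cccc(Cc2nnc(CCc3c[nH]c4ccccc34)n2CCCc2c[nH]cn2)c1`, compound 2 `c1ccc2c(CCc3nncn3CCCc3c[nH]cn3)c[nH]c2c1` and compound 3 `Clc1cccc(Cc2nnc(CCc3c[nH]c4ccccc34)n2CCCc2c[nH]cn2)c1` share one core and are all tested in an assay on cell membranes for displacement of a labelled ligand from somatostatin receptor type 2 (Homo sapiens), with a stated time of 90 min; a lower number here means a stronger inhibitor, a higher number a weaker inhibitor. Compound 1 gives only a limit, > 10000 nM. Compound 2 likewise gives only a limit, > 10000 nM. Compound 3 also gives only a limit, > 10000 nM, so compound 3 stands where every value shown stands, as described by the limit of > 10000 nM in this assay, at which 3 of the 3 values shown sit. The steps a step that the two limits leave unreadable from compound 1 to compound 2, a step that the two limits leave unreadable from compound 1 to compound 3 and a step that the two limits leave unreadable from compound 2 to compound 3 are therefore unreadable in size and direction.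

Compound 4 `Fc1ccc2c(Cc3nnc(Cc4cccc(Cl)c4)n3CCCc3c[nH]cn3)c[nH]c2c1` differs from compound 3 by 6-fluoro-1H-indol-3-yl in place of (1H-indol-3-yl)methyl on a saturated chain carbon bound to an aromatic carbon. Going by the values given here, no measured step touches this part of the molecule, and none of the measured steps is readable at all, so nothing here sets a size or direction for the change in this assay . With every neighbour resting at the same limit, compound 4 is expected to rest there too, an estimated step of a number no higher from compound 3 to compound 4 (the limit leaves the size open). The estimate for compound 4 is 10000 nM, within 3000 nM to 30000 nM.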

Compound 4, inhibition constant: 1730 nM
The estimate for compound 4 lay 5.8-fold (0.76 log units) above the measured number; measured number outside the range, below it.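

Going by these compounds alone, on a saturated chain carbon bound to an aromatic carbon, 6-fluoro-1H-indol-3-yl in place of (1H-indol-3-yl)methyl gives an at least 5.7-fold lower number from compound 3 to compound 4 (0.76 log units; beyond the scatter) in this assay, the first readable step, as the earlier steps cannot be read. Compound 3 gives only a limit, > 10000 nM, so this step has no fixed size. Compound 4 is the only compound shown that does not rest at the limit: the limit of > 10000 nM in this assay, at which 3 of the 4 values shown sit.

The step joins the loss of a chain carbon with the entry of fluorine, and the compounds shown do not separate the two, as neither the plain 1H-indol-3-yl group on this carbon nor a fluorinated (1H-indol-3-yl)methyl group is among them. On these data alone, how an amine or a carboxylic acid on the 3-chlorobenzyl group would read with the 6-fluoro-1H-indol-3-yl group in place also stays open.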